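Replacing a Bromopyridinyl Group with Chlorophenyl

The compounds below may be only part of what the source reports. "The series", "measured", "known", "first", "only" and "open" are said of these compounds alone.

Three measured compounds share one core and differ only in the group attached on a saturated chain carbon bound to an amide-type nitrogen. Compound 1 `Nc1ccccc1NC(=O)c1ccc(NC(=S)NCc2cncc(Br)c2)cc1` gives 9200 nM in a functional assay on HCT-116 cells (Homo sapiens) for cytotoxicity, read by MTT assay, with a stated time of 72 h; a higher number here means a weaker inhibitor, a lower number a stronger inhibitor. Compound 2 `Cc1ccc(CNC(=S)Nc2ccc(C(=O)Nc3ccccc3N)cc2)cn1` gives 11000 nM, and compound 3 `Nc1ccc(CNC(=O)Nc2ccc(C(=O)Nc3ccccc3N)cc2)cn1` gives 7300 nM. All three numbers lie within the scatter of one another, so compound 1 stands among them without any clear order. Compound 4 `Nc1ccccc1NC(=O)c1ccc(NC(=S)NCc2cccc(Cl)c2)cc1` is not yet measured. Its change from compound 1 is 3-chlorophenyl in place of 5-bromopyridin-3-yl on a saturated chain carbon bound to an amide-type nitrogen. For the measured compounds named here, the one measured step at this same place, a 1.2-fold higher number from compound 1 to compound 2 (0.08 log units; within the scatter), stayed within the scatter. A similar outcome is therefore expected for compound 4, with an expected step of a 1.0-fold lower number from compound 1 to compound 4 (0.01 log units; within the scatter). Compound 4 is estimated at 9000 nM, within a range of 4000 nM to 20000 nM.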

Compound 4, half-maximal inhibitory concentration: 5900 nM
Compound 4: the middle estimate sits 1.5-fold (0.18 log units) above what was measured, within the range that was stated.
By their numbers in this assay, from the lowest: compounds 4, 3, 1 and 2 (each within the scatter of the next).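

Putting a ring of carbon only at this place keeps the step within the scatter (a 1.6-fold lower number from compound 1 to compound 4 (0.19 log units; within the scatter)), and the same holds when the 6-methylpyridin-3-yl group is the one replaced (a 1.9-fold lower number from compound 2 to compound 4 (0.27 log units; within the scatter)). The pyridine ring nitrogen, with its hydrogen-bond acceptor, can therefore be lost without a clear shift in this cell read-out, although bromine also gives way to chlorine in the first step, and the two changes cannot be separated. Nothing available explains these numbers. On these data alone, whether a carboxylic acid or an amine on this carbon would give a step beyond the scatter remains open.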